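This account rests on a few compounds, and the source may have more. Where it says the series, first, only, none or still open, it means among the compounds named here.

Compound 1 `O=C(CSc1nnc(-c2ccncc2)n1-c1ccccc1)N/N=C/c1ccccc1` gives 23600 nM in a functional assay on MCF7 cells (Homo sapiens) for inhibition, read by MTT assay, with a stated time of 48 h; on this read-out lower numbers stand for stronger inhibition and higher numbers for weaker inhibition; compound 2 `O=C(CSc1nnc(-c2ccncc2)n1-c1ccccc1)N/N=C/c1ccccc1O` gives 10000 nM in this assay.

Compound 2 holds the lowest number of the two, its nearest neighbour being compound 1, separated by a 2.4-fold lower number from compound 1 to compound 2 (0.37 log units; beyond the scatter), a modest step beyond the scatter. Compound 3 `O=C(CSc1nnc(-c2ccncc2)n1-c1ccccc1)N/N=C/c1cc(Br)cc(Br)c1O` differs from compound 2 by 3,5-dibromo-2-hydroxyphenyl in place of 2-hydroxyphenyl on a carbon with a double bond to nitrogen. Within the data shown here, no measured step introduces bromine on that ring; the one step that bears on it shows only that a change on this ring can shift the number modestly. A modest downward step is therefore expected: a 2.5-fold lower number from compound 2 to compound 3 (0.40 log units; beyond the scatter). Compound 3 is estimated at 4000 nM, within 1000 nM to 15000 nM.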

Compound 3, half-maximal inhibitory concentration: 8440 nM
Estimate against measurement, compound 3: 2.1-fold (0.32 log units) below; low and high end bracket the measured number.
By their numbers in this assay, from the lowest: compounds 3 and 2 (each within the scatter of the next); then compound 1.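

In this assay, 3,5-dibromo-2-hydroxyphenyl and 2-hydroxyphenyl cannot be told apart at this position (a 1.2-fold lower number from compound 2 to compound 3 (0.07 log units; within the scatter)). The dibromo group still keeps a modest step over plain phenyl (a 2.8-fold lower number from compound 1 to compound 3 (0.45 log units; beyond the scatter)), so adding the two bromines to the hydroxylated ring brings no change that can be read beyond the scatter. No evidence is available that accounts for this result.

As far as these compounds go, what bromine would do on a ring without the hydroxy stays open. So does the effect of a methoxy group or an amine in place of that hydroxy.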